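The source may hold more compounds than are shown below. What is called first, only, known or untested is meant among the compounds shown, and "the series" means these compounds.

Working notes on the series. Compound 1 `COc1ccccc1C(=O)/C=C/c1ccc2ccccc2c1` in an ADME assay on M210B4 cells (Mus musculus) for cytotoxicity, with a stated time of 48 h (on this read-out higher numbers stand for weaker inhibition and lower numbers for stronger inhibition), gives 42000 nM. Compound 2 `CCCCOc1ccccc1C(=O)/C=C/c1ccc2ccccc2c1` in this assay gives > 100000 nM, which is a limit of the assay and not a number. Compound 2 thus sits at the weak end of what has been measured, and the step of an at least 2.3-fold higher number from compound 1 to compound 2 (0.37 log units; beyond the scatter) rests on (the limit of > 100000 nM in this assay, at which 1 of the 2 values shown sits). Compound 3 `Cc1ccccc1C(=O)/C=C/c1ccc2ccccc2c1` carries the change (methyl in place of butoxy on an aromatic carbon). Among the measured compounds shown here, only that one measured step bears on it, and it points the opposite way, since shortening toward compound 1 gave 42000 nM. For compound 3 a step of an at least 2.0-fold lower number from compound 2 to compound 3 (0.30 log units; that floor lies within the scatter) is therefore expected. Compound 3 is estimated at 50000 nM, within 20000 nM to 150000 nM.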

Compound 3, half-maximal inhibitory concentration: 72000 nM
Compound 3: middle estimate off by 1.4-fold (0.16 log units), on the low side, and the stated range covers the measured number.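

Methyl in place of methoxy on an aromatic carbon gives a 1.7-fold higher number from compound 1 to compound 3 (0.23 log units; within the scatter), so in this assay this exchange at the position stays within the scatter. Methyl in place of butoxy gives an at least 1.3-fold lower number from compound 2 to compound 3 (0.14 log units; that floor lies within the scatter), which is a floor only. Compound 2 is held by a limit of the assay and not a number: the limit of > 100000 nM in this assay, at which 1 of the 3 values shown sits.

As far as these compounds go, what an amine or a carboxylic acid on this aromatic carbon would give stays open. So does how an ethoxy chain would read against methoxy and butoxy.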